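Methoxy for Chloro on the Thiourea Aryl of Compound 1

This account rests on a few compounds, and the source may have more. Where it says the series, first, only, none or still open, it means among the compounds named here.

Going by the values given here, compound 1 `NC(=O)c1c(NC(=O)c2ccccc2C(F)(F)F)sc2c1CCN(C(=S)Nc1ccccc1Cl)C2` stands at the high end of the two numbers known: in a functional assay on MKN-74 cells (Homo sapiens) for antiproliferative activity, with a stated time of 24 h (a higher number here means a weaker inhibitor, a lower number a stronger inhibitor), compound 1 gives 21900 nM, whereas compound 2 `NC(=O)c1c(NC(=O)c2cccc([N+](=O)[O-])c2)sc2c1CCN(C(=S)Nc1ccccc1Cl)C2` gives 8850 nM, and a 2.5-fold lower number from compound 1 to compound 2 (0.39 log units; beyond the scatter) came from 3-nitrophenyl in place of 2-(trifluoromethyl)phenyl on a carbonyl carbon. Compound 3 `COc1ccccc1NC(=S)N1CCc2c(sc(NC(=O)c3ccccc3C(F)(F)F)c2C(N)=O)C1` differs from compound 1 elsewhere: methoxy in place of chloro on an aromatic carbon. Among the compounds with values here, no measured step touches that part of the molecule, so the nitro step gives no direct guide, and a change within the scatter is expected. Compound 3 is therefore estimated at 20000 nM in this assay, within 7000 nM to 60000 nM. The expected step is a 1.1-fold lower number from compound 1 to compound 3 (0.04 log units; within the scatter).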

Compound 3, half-maximal inhibitory concentration: 34500 nM
Compound 3: middle estimate off by 1.7-fold (0.24 log units), on the low side; low and high end bracket the measured number.
By their numbers in this assay, from the lowest: compound 2; then compounds 1 and 3 (each within the scatter of the next).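

At this position, ortho to a large group, methoxy in place of chloro gives a 1.6-fold higher number from compound 1 to compound 3 (0.20 log units; within the scatter) in this assay. Compound 1 and compound 3 therefore cannot be told apart in this assay, even though methoxy brings a hydrogen-bond acceptor that chloro lacks. No supporting evidence bears on this result.

Going by these compounds, it remains open whether an amine or a carboxylic acid on the same aromatic carbon would also leave the number unmoved. Also open, on these data alone, is whether methoxy would behave the same way with the 3-nitrophenyl group of compound 2.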